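Methoxy to hydroxy on a pyrazole urea series

This account rests on a few compounds, and the source may have more. Where it says the series, first, only, none or still open, it means among the compounds named here.

Compound 1, `O=C(Nc1cccc(-n2cc(-c3ccncc3)c(-c3ccc(Cl)c(O)c3)n2)c1)Nc1cccc(C(F)(F)F)c1`, gives 1950 nM in a functional assay on SF-268 cells (Homo sapiens) for inhibition, read by sulforhodamine B assay, with a stated time of 48 h; on this read-out lower numbers stand for stronger inhibition of growth and higher numbers for weaker inhibition of growth.
Compound 2, `O=C(Nc1cccc(-n2cc(-c3ccncc3)c(-c3ccc(Cl)c(O)c3)n2)c1)Nc1ccc(Cl)c(Cl)c1`, gives 1490 nM in this assay.
Compound 3, `COc1cc(-c2nn(-c3cccc(NC(=O)Nc4ccc(Cl)c(C(F)(F)F)c4)c3)cc2-c2ccncc2)ccc1Cl`, gives 1460 nM in this assay.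

Compound 3 stands within the scatter of both measured neighbours: compound 2 sits nearest to it, and compound 1 sits furthest, both gaps inside the scatter. For the measured compounds named here, the one measured step, a 1.3-fold lower number from compound 1 to compound 2 (0.12 log units; within the scatter), concerns the aryl on the amide-type nitrogen and not the ring that changes here. Compound 4, `O=C(Nc1cccc(-n2cc(-c3ccncc3)c(-c3ccc(Cl)c(O)c3)n2)c1)Nc1ccc(Cl)c(C(F)(F)F)c1`, differs from compound 3 by hydrogen in place of methyl on an oxygen on an aromatic ring. Going by the values given here, no measured pair addresses this methoxy-to-hydroxy change. Among the compounds with values here, compounds 1 and 2 carry the 4-chloro-3-hydroxyphenyl group with other urea aryls, and their numbers in this assay fall in the same band as compound 3, so the series so far shows no step beyond the scatter. Compound 4 is therefore expected to move by about a 1.0-fold higher number from compound 3 to compound 4 (0.01 log units; within the scatter), no further than the scatter. The estimate for compound 4 in this assay is 1500 nM, with a range from 700 nM to 3500 nM.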

Compound 4, concentration for 50% growth inhibition: 1060 nM
For compound 4 the middle estimate is 1.4-fold (0.15 log units) above the measured one; the measured number falls inside the stated range.
By their numbers in this assay, from the lowest: compounds 4, 3, 2 and 1 (each within the scatter of the next).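

In this assay the methoxy-to-hydroxy change now has its first measured pair, and a 1.4-fold lower number from compound 3 to compound 4 (0.14 log units; within the scatter) shows that, with this urea aryl, the oxygen on the aromatic ring can carry methyl or hydrogen without a step beyond the scatter. With the 4-chloro-3-hydroxyphenyl group held constant, trifluoromethyl in place of chloro gives a 1.4-fold lower number from compound 2 to compound 4 (0.15 log units; within the scatter) and chloro in place of hydrogen gives a 1.8-fold lower number from compound 1 to compound 4 (0.26 log units; within the scatter) on the urea aryl, so neither of these changes leaves the scatter either. Nothing measured here explains why the numbers stay so close.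

The compounds shown leave open whether a longer chain on that oxygen, such as ethyl, or an amine in place of the hydroxy would give a step beyond the scatter. They also leave open whether the methoxy-to-hydroxy result holds with the urea aryls of compound 1 and compound 2, since neither has a methoxy partner here.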